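Halogen swap on the ring double bond of compound 1

A few compounds are considered here, and "the series" means these few. Any claim that something is new, unique, unknown or untested is made for them only; others in the source may bear on it.

Measured compounds in a functional assay on WiDr cells (Homo sapiens) for antiproliferative activity, read by sulforhodamine B assay, with a stated time of 48 h; a higher number here means a weaker inhibitor of growth, a lower number a stronger inhibitor of growth:
Compound 1 `Cc1ccc(S(=O)(=O)N2CC=C(Cl)CC2)cc1` gives > 100000 nM, which is a limit of the assay and not a number.
Compound 2 `Cc1ccc(S(=O)(=O)N2CCC(Cl)=CC2CC(C)C)cc1` gives 21000 nM.
Compound 3 `CCCCCCCC1C=C(Cl)CCN1S(=O)(=O)c1ccc(C)cc1` gives 50000 nM.

Among the measured compounds shown here, compound 1 stands at the limit, as the limit of > 100000 nM in this assay, at which 1 of the 3 values shown sits, records; among the values shown it is the only compound without a number. The unmeasured compound 4 `Cc1ccc(S(=O)(=O)N2CC=C(Br)CC2)cc1` differs from it in one place: bromo in place of chloro on a double-bonded ring carbon. For the measured compounds named here, none of the measured steps touches this position. The two steps from compound 1 put an alkyl chain on a saturated ring carbon: an at least 4.7-fold lower number from compound 1 to compound 2 (0.67 log units; beyond the scatter) and an at least 2.0-fold lower number from compound 1 to compound 3 (0.30 log units; that floor lies within the scatter). The step of a 2.4-fold higher number from compound 2 to compound 3 (0.38 log units; beyond the scatter) changes the chain on that same saturated carbon. All three steps concern the saturated carbon, not the halogen on the double-bonded ring carbon, so they give no direct measure of a chloro to bromo exchange. The expectation for compound 4 is therefore no step beyond the scatter, and the value is expected to remain at or near the limit. For compound 4 the estimate in this assay is 150000 nM, within 50000 nM to 500000 nM. This estimate implies an expected step that the limit leaves unreadable from compound 1 to compound 4.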

Compound 4, concentration for 50% growth inhibition: > 100000 nM
Compound 4: no number, only a limit; the forecaster's own chance of this, stated with the estimate: 75%; the middle value does not contradict the limit.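

Compound 1 and compound 4 both stand at a limit and not at a number, so no step can be read for bromo in place of chloro on a double-bonded ring carbon: the limit of > 100000 nM in this assay, at which 2 of the 4 values shown sit.

The compounds shown leave open whether this exchange alters growth inhibition at all, and what it would do in a compound bearing an alkyl chain, such as compound 2.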